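The source may hold more compounds than are shown below. What is called first, only, known or untested is meant among the compounds shown, and "the series" means these compounds.

Measured so far in a functional assay on GBM2 cells (Homo sapiens) for antiproliferative activity, read by WST assay, with a stated time of 72 h; on this read-out lower numbers stand for stronger inhibition and higher numbers for weaker inhibition:
- compound 1 `O=C(Nc1ccc(C(F)(F)F)cc1)Nc1cc2ncncc2cc1OCc1cccc(F)c1`: 3200 nM
- compound 2 `O=C(Nc1ccc(Cl)c(Cl)c1)Nc1cc2ncncc2cc1OCc1ccccc1F`: 6000 nM
- compound 3 `O=C(Nc1ccccc1F)Nc1cc2ncncc2cc1OCc1ccccc1F`: 3600 nM

Compound 3, at 3600 nM, lies within the scatter of both other compounds, so the three numbers give no real order. Compound 4 `O=C(Nc1ccccc1F)Nc1cc2ncncc2cc1OCc1cccc(F)c1` differs from it by 3-fluorophenyl in place of 2-fluorophenyl on a saturated chain carbon bound to an oxygen on an aromatic ring.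

Among the compounds with values here, no measured step covers this place. The one available, a 1.7-fold lower number from compound 2 to compound 3 (0.22 log units; within the scatter), concerns a change on an amide-type nitrogen and bears only indirectly. Compound 1 already carries 3-fluorobenzyl and gives 3200 nM, though it also differs elsewhere.

An estimated 1.1-fold lower number from compound 3 to compound 4 (0.02 log units; within the scatter) therefore means no expected step beyond the scatter in this assay. The expected value for compound 4 is 3400 nM, with an estimated range of 1700 nM to 7000 nM.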

Compound 4, half-maximal inhibitory concentration: 6400 nM
The estimate for compound 4 lay 1.9-fold (0.27 log units) below the measured number, within the range that was stated.
By their numbers in this assay, from the lowest: compounds 1, 3, 2 and 4 (each within the scatter of the next).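

Within the data shown here, the first step at this place reads a 1.8-fold higher number from compound 3 to compound 4 (0.25 log units; within the scatter) in this assay, so 2-fluorobenzyl and 3-fluorobenzyl are not separated on the oxygen. On the amide-type nitrogen, the step reads a 2.0-fold higher number from compound 1 to compound 4 (0.30 log units; within the scatter), so 4-(trifluoromethyl)phenyl and 2-fluorophenyl are not separated either. No measured evidence offers an explanation for either step.

Still open, on these data alone, is whether an amine or a carboxylic acid on the benzyl group, or a longer chain in place of that group, would give a step beyond the scatter.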